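Lengthening the Ester Chain by One Carbon

The source may hold more compounds than are shown below. What is called first, only, known or untested is meant among the compounds shown, and "the series" means these compounds.

Three compounds share one core and differ only in the length of a saturated chain attached through an oxygen next to a carbonyl group. In a functional assay on A549 cells (Homo sapiens) for cytotoxicity, read by MTT assay, with a stated time of 24 h, tested at 80 uM (a higher number here means a weaker effect of the compound at the concentration tested, a lower number a stronger effect), compound 1 `CCCCCCCOC(=O)CCC(=O)N1CCN(CCCOc2cc3c(Nc4ccc(F)c(Cl)c4)ncnc3cc2OC)CC1` gives 27.2%. Compound 2 `CCCCCCCCOC(=O)CCC(=O)N1CCN(CCCOc2cc3c(Nc4ccc(F)c(Cl)c4)ncnc3cc2OC)CC1` carries methyl in place of hydrogen on a saturated chain carbon, seven bonds along the chain from an oxygen next to a carbonyl group; in this assay compound 2 gives 21.7%, and the step of a number 5.5 percentage points lower from compound 1 to compound 2 (within the scatter) is small. Compound 3 `CCCCCCCCCCCCCCCCCCOC(=O)CCC(=O)N1CCN(CCCOc2cc3c(Nc4ccc(F)c(Cl)c4)ncnc3cc2OC)CC1` differs from compound 1 by undecyl in place of hydrogen on a saturated chain carbon, seven bonds along the chain from an oxygen next to a carbonyl group; in this assay compound 3 gives 86.7%, a large shift, seen as a number 59.5 percentage points higher from compound 1 to compound 3 (beyond the scatter) and as a number 65 percentage points higher from compound 2 to compound 3 (beyond the scatter). Compound 4 `CCCCCCCCCCCCCCCCCCCOC(=O)CCC(=O)N1CCN(CCCOc2cc3c(Nc4ccc(F)c(Cl)c4)ncnc3cc2OC)CC1` has not yet been measured. Its difference from compound 3 is methyl in place of hydrogen on a saturated chain carbon, ten or more bonds along the chain from an oxygen next to a carbonyl group, the same kind of change, a methyl in place of hydrogen, as from compound 1 to compound 2. Because the earlier step of a number 5.5 percentage points lower from compound 1 to compound 2 (within the scatter) stayed within the scatter, the step from compound 3 to compound 4 is expected to be small as well, about a number 1.7 percentage points lower from compound 3 to compound 4 (within the scatter). Compound 4 is therefore estimated at 85% in this assay, with a likely range from 70% to 98%.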

Compound 4, a percentage reported as activity, at one concentration (the size of the read-out at that concentration, not a potency): 88.4%
The estimate for compound 4 lay 3.4 percentage points below the measured number, within the range that was stated.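

In this assay, one extra carbon at the far end of the long chain gives a number 1.7 percentage points higher from compound 3 to compound 4 (within the scatter), and this small step matches the one seen with the shorter chains: the same change on two cores in this assay, a number 5.5 percentage points lower (within the scatter) from compound 1 to compound 2 and a number 1.7 percentage points higher (within the scatter) from compound 3 to compound 4, 7.2 percentage points apart, within the scatter of two such steps

The large lengthening also carries over, with a number 66.7 percentage points higher from compound 2 to compound 4 (beyond the scatter) and a number 61.2 percentage points higher from compound 1 to compound 4 (beyond the scatter), and the two steps that can be set side by side agree: the same change on two cores in this assay, a number 59.5 percentage points higher (beyond the scatter) from compound 1 to compound 3 and a number 66.7 percentage points higher (beyond the scatter) from compound 2 to compound 4, 7.2 percentage points apart, within the scatter of two such steps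

This shows that each change had a similar size in these few pairs, but it does not explain why, and it does not show that adding one carbon leaves the number unchanged at every chain length, since the large rise lies somewhere between the chains of compound 2 and compound 3.

The compounds shown leave open where along that stretch of chain lengths the rise occurs, and whether it is gradual or abrupt. They also leave open how a chain ending in an amine or a carboxylic acid would behave in this assay.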